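Adding a propoxy group to compound 3

The source may hold more compounds than are shown below. What is called first, only, known or untested is meant among the compounds shown, and "the series" means these compounds.

In a functional assay on V79 cells (Cricetulus griseus) for cytotoxicity (on this read-out lower numbers stand for stronger inhibition and higher numbers for weaker inhibition), compound 1 (`COc1ccc2c(c1CCC(C)C)OC(=O)CC2`) reads > 100000 nM, which is a limit of the assay and not a number. Compound 2 (`CC(C)CCc1c(O)ccc2c1OC(=O)CC2`) reads > 100000 nM, which is also a limit. Among the compounds with values here, compound 3 (`CC(C)CCc1cccc2ccc(=O)oc12`) gives 60000 nM, the only actual number among the three.

Compound 4 (`CCCOc1ccc2ccc(=O)oc2c1CCC(C)C`) has not yet been measured. It differs from compound 3 in one place: propoxy in place of hydrogen on an aromatic carbon. In words, propoxy takes the place of hydrogen on an aromatic carbon, ortho to the isopentyl group.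

Within the data shown here, only one measured step involves a group on an oxygen on an aromatic ring: a step that the two limits leave unreadable from compound 1 to compound 2. It swaps hydrogen for methyl, and since both ends are limits, it shows neither a size nor a direction. The wider picture is the limit of > 100000 nM in this assay, at which 2 of the 3 values shown sit. Among the measured compounds shown here, no measured step therefore shows what adding propoxy does, so no shift beyond the usual scatter can be predicted with any confidence, and a reading at the limit remains possible.

The expected change is small, an estimated 1.2-fold higher number from compound 3 to compound 4 (0.07 log units; within the scatter). For compound 4 the estimated value is 70000 nM, with an expected range of 30000 nM to 100000 nM.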

Compound 4, half-maximal inhibitory concentration: 5600 nM
For compound 4 the middle estimate is 13-fold (1.10 log units) above the measured one; measured number outside the range, below it.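

In this assay, the aromatic carbon ortho to an isopentyl group proves sensitive to what it carries: with propoxy in place of hydrogen, the read-out shows an 11-fold lower number from compound 3 to compound 4 (1.03 log units; beyond the scatter). Within the data shown here, this is the first readable effect of any change, and it points toward stronger inhibition in this test of cell toxicity. Among these compounds, the earlier compounds could not show this: their only step, hydrogen in place of methyl on an oxygen on an aromatic ring, cannot be read, and it says nothing about what adding a group to this carbon does.

A single group at a single place cannot show whether the effect belongs to propoxy itself or would come with almost any substituent, and a longer chain such as butoxy, or an amine on the same carbon, would help to tell these apart. It also stays open whether propoxy would have a similar effect on the shared core of compounds 1 and 2, as each of those two compounds reads only as a limit and not as a number: the limit of > 100000 nM in this assay, at which 2 of the 4 values shown sit.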